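A Second Ring Methyl on the Core of Compound 2

The source may report more compounds than this note shows. Statements on the series, on what has been measured and on what is new or still open speak of the compounds shown alone.

Compound 1 `CN(C)C(=O)c1cccnc1NCCCN1CCN(c2ccccc2)CC1` and compound 2 `Cc1ccccc1N1CCN(CCCNc2ncccc2C(=O)N(C)C)CC1` share one core. In an assay on isolated protein for displacement of a labelled ligand from Alpha-1A adrenergic receptor (Bos taurus) (a higher number here means a weaker inhibitor, a lower number a stronger inhibitor), compound 1 gives 2 nM and compound 2 gives 0.794 nM, the lowest of the two numbers, reached by a 2.5-fold lower number from compound 1 to compound 2 (0.40 log units; beyond the scatter). Compound 3 `Cc1cccc(C)c1N1CCN(CCCNc2ncccc2C(=O)N(C)C)CC1` carries methyl in place of hydrogen on an aromatic carbon, the same difference read one bond further out as 2-methylphenyl to 2,6-dimethylphenyl. Going by the values given here, only that one measured step bears on it, and a repeat of the same change need not repeat its size, so a small lowering or none beyond the scatter is expected in this assay. Compound 3 is therefore estimated at 0.6 nM, with a range of 0.2 nM to 2 nM. This means an expected step of a 1.3-fold lower number from compound 2 to compound 3 (0.12 log units; within the scatter).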

Compound 3, inhibition constant: 7.94 nM
Compound 3: the middle estimate sits 13-fold (1.12 log units) below what was measured; the measured number lies above the stated range.
By their numbers in this assay, from the lowest: compound 2; then compound 1; then compound 3.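

In this assay the same change now runs the other way, with a 10-fold higher number from compound 2 to compound 3 (1.00 log units; beyond the scatter) where the first methyl had lowered the number. Set against the unsubstituted phenyl, the 2,6-dimethylphenyl group gives a 4.0-fold higher number from compound 1 to compound 3 (0.60 log units; beyond the scatter) and so keeps no gain at all, which shows that the outcome of adding a methyl on this ring depends on the methyl already there. Nothing available here explains this reversal. As far as these compounds go, what a 2-ethylphenyl or 2-methoxyphenyl group would give remains open, as does whether a second substituent such as chlorine would raise the number as the second methyl does.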